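This account rests on a few compounds, and the source may have more. Where it says the series, first, only, none or still open, it means among the compounds named here.

Compound 1 (`O=S(=O)(CS(=O)(=O)C(F)(F)F)c1ccc(OC(F)(F)F)cc1`) gives 2.2 in a physicochemical assay for lipophilicity, read by HPLC; a higher number here means a more lipophilic compound, a lower number a more polar compound. Compound 2 (`CC(C)(C)c1ccc(S(=O)(=O)CS(=O)(=O)C(F)(F)F)cc1`) gives 2.4, which places the two within the scatter of each other, and no other measured number is available to place compound 1. Compound 3 (`O=S(=O)(CS(=O)(=O)C(F)(F)F)c1ccc(F)cc1`) is still unmeasured. Its difference from compound 1 is fluoro in place of trifluoromethoxy on an aromatic carbon, para to a large group. Within the data shown here, the only measured step bearing on this is a number 0.20 log units higher from compound 1 to compound 2 (within the scatter), where tert-butyl takes the place of the same trifluoromethoxy. Among the measured compounds shown here, that is a different replacement, and the series holds no measured fluoro example, so it guides the size only loosely. A modest downward step in this assay is expected, with fluoro the smaller group entering. The expected step is a number 0.50 log units lower from compound 1 to compound 3 (beyond the scatter). For compound 3 the estimated value is 1.7, with an expected range of 1.2 to 2.1.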

Compound 3, partition coefficient: 1.3
Compound 3: middle estimate off by 0.40 log units, on the high side, and the stated range covers the measured number.
By their numbers in this assay, from the lowest: compound 3; then compounds 1 and 2 (each within the scatter of the next).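

At this aromatic carbon, para to a large group, the number in this assay can move beyond the scatter: fluoro in place of trifluoromethoxy gives a number 0.90 log units lower from compound 1 to compound 3 (beyond the scatter) and fluoro in place of tert-butyl gives a number 1.10 log units lower from compound 2 to compound 3 (beyond the scatter) on the shared core. The earlier step, a number 0.20 log units higher from compound 1 to compound 2 (within the scatter), showed no separation between trifluoromethoxy and tert-butyl, so among these three groups fluoro alone stands apart, and the position is clearly not indifferent to what sits there. No measurement in hand accounts for the size of these steps.

Among these compounds, with only three groups, it remains open whether the number follows the heavy atom count of the group or something else. As far as these compounds go, how an amine, a carboxylic acid or a longer chain at this place would read in this assay also remains open.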